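A few compounds are considered here, and "the series" means these few. Any claim that something is new, unique, unknown or untested is made for them only; others in the source may bear on it.

Compound 1, with the structure `COc1cccc(N2CCN(C(=O)C(C)N3C(=O)CCC3=O)CC2)c1`, shows in a functional assay on the whole organism (strain Swiss) with Mus musculus as the target, in the maximal electroshock model, with a stated time of 2 h, at a dose of 100 mg/kg by the intraperitoneal route (a lower number here means a weaker effect, a higher number a stronger effect of the compound at the dose given), a read-out of 0%, that is, no measurable protection at the dose tested. Compound 2, with the structure `CC(C(=O)N1CCN(c2ccccc2F)CC1)N1C(=O)CCC1=O`, gives in this assay a read-out of 0%. Going by the values given here, the one measured step, no change at the digits printed from compound 1 to compound 2 (within the scatter), therefore lies flat: swapping one ring-bound aryl group for another left the read-out unchanged. On the numbers shown, compound 2 stands level with compound 1 and neither can be called the more active.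

Compound 3, with the structure `CC(C(=O)N1CCN(c2ccc(F)cc2)CC1)N1C(=O)CCC1=O`, is not yet measured. Its difference from compound 2 is 4-fluorophenyl in place of 2-fluorophenyl on an amine nitrogen in a ring; the two share every atom and differ only in how they are joined. Among the compounds with values here, no measured pair shows exactly this kind of change, so the expectation rests on the single flat step from compound 1 to compound 2 and on the fact that both measured compounds sit at the bottom of the scale. For compound 3 the expected step is no change at the digits printed from compound 2 to compound 3 (within the scatter), that is, no change beyond the scatter. Compound 3 is estimated at 0%, within a range from 0% to 15%.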

Compound 3, a percentage reported as activity, at one dose (the size of the read-out at that dose, not a potency): 0%
Estimate against measurement, compound 3: no gap at the digits printed; the range from low to high includes it.
By their numbers in this assay, from the lowest: compounds 1, 2 and 3 (each within the scatter of the next).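

Exchanging 2-fluorophenyl for 4-fluorophenyl on the amine nitrogen in the ring keeps the same atoms and changes only how they are joined, and this assay records no change at the digits printed from compound 2 to compound 3 (within the scatter). Exchanging 3-methoxyphenyl for 4-fluorophenyl at the same place gives no change at the digits printed from compound 1 to compound 3 (within the scatter), so three different aryl groups on this nitrogen now share one read-out, at the bottom of the scale, and moving the fluorine brings no protection into view. No independent measurement bears on why these read-outs coincide.

With all three compounds at the bottom of the scale, a change that would weaken the effect cannot be seen here, so the flat steps do not show that the aryl group has no influence on activity, and nothing shown speaks to other doses or times. From the compounds shown here alone, whether a different group on this nitrogen, such as 3-chlorophenyl, 3-trifluoromethylphenyl or benzyl, would lift the read-out off the bottom of the scale remains open.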